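Adding a Trifluoromethyl to the Distal Phenyl

The source may report more compounds than this note shows. Statements on the series, on what has been measured and on what is new or still open speak of the compounds shown alone.

Three analogues sharing one core have been tested in a functional assay on HCT-116 cells (Homo sapiens) for antiproliferative activity, read by MTT assay, with a stated time of 72 h; a lower number here means a stronger inhibitor, a higher number a weaker inhibitor. Compound 1 `O=C(CCc1cccc2c1B(O)OC2)Nc1ccc(Cl)cc1` gives 12000 nM. Among the compounds with values here, compound 2 `COc1ccc(NC(=O)CCc2cccc3c2B(O)OC3)cc1` gives 1700 nM, and the step of a 7.1-fold lower number from compound 1 to compound 2 (0.85 log units; beyond the scatter) is the only single-point comparison so far recorded. Compound 3 `O=C(CCc1cccc2c1B(O)OC2)Nc1cccc(-c2ccccc2)c1` gives 890 nM, the lowest of the three numbers; against compound 2 the gap is within the scatter, while against compound 1 it is beyond it, so compound 3 and compound 2 cannot be ranked against each other on these numbers.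

Compound 4 `O=C(CCc1cccc2c1B(O)OC2)Nc1cccc(-c2cccc(C(F)(F)F)c2)c1` differs from compound 3 by trifluoromethyl in place of hydrogen on an aromatic carbon. Within the data shown here, no measured step involves this group or this outer ring; the one step on record, a 7.1-fold lower number from compound 1 to compound 2 (0.85 log units; beyond the scatter), concerns a different group on a different ring. That step offers no guide here, so for compound 4 the expectation in this assay is a change no larger than the scatter, an estimated step of a 1.3-fold lower number from compound 3 to compound 4 (0.10 log units; within the scatter). Compound 4 is therefore expected to give about 700 nM, with a range from 250 nM to 2000 nM.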

Compound 4, half-maximal inhibitory concentration: 580 nM
Beside the measured number, compound 4's estimate is 1.2-fold (0.08 log units) above it; measured number inside the range.
By their numbers in this assay, from the lowest: compounds 4, 3 and 2 (each within the scatter of the next, the first and the last beyond it); then compound 1.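

In this assay, the change from phenyl to 3-(trifluoromethyl)phenyl gives a 1.5-fold lower number from compound 3 to compound 4 (0.19 log units; within the scatter), so adding four heavy atoms at this place on the outer ring leaves the number within the usual scatter of repeated measurements. Within the data shown here, this is the first measured step on the outer ring. Among these compounds, the only earlier step concerned a different group on a different ring. This new step shows that this position can carry trifluoromethyl without a change that can be told apart from that scatter. Nothing measured here offers an explanation for this result, so the step stands as an observation without a known cause.

Among the compounds shown here, whether an amine, a carboxylic acid or a longer chain at the same place would also leave the number within the scatter remains open, since trifluoromethyl is the only group compared with hydrogen here. Also open, on these data alone, is whether trifluoromethyl elsewhere on the outer ring would behave in the same way, as one change in one place cannot establish a trend.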